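The compounds below may be only part of what the source reports. "The series", "measured", "known", "first", "only" and "open" are said of these compounds alone.

Of the compounds shown here, two have been measured so far in an assay on isolated protein (Cavia porcellus) with Sigma non-opioid intracellular receptor 1 (Homo sapiens) as the target, read by radioligand binding; on this read-out lower numbers stand for stronger inhibition and higher numbers for weaker inhibition. Compound 1 `O=c1cc(-c2ccccc2)oc2cccc(OCCCCN3CCC(O)CC3)c12` gives 177 nM. Compound 2 `CN(C)CCCCCCCCOc1ccc2oc(-c3ccccc3)cc(=O)c2c1` gives 143 nM, a number that lies within the usual scatter of the value for compound 1, so the two cannot be told apart. Compound 3 `O=c1cc(-c2ccccc2)oc2ccc(OCCCCCCN3CCCCC3)cc12` is not yet measured; it differs from compound 2 in one place: piperidin-1-yl in place of 2-(dimethylamino)ethyl on a saturated chain carbon, six bonds along the chain from an oxygen on an aromatic ring. For the measured compounds named here, with no measured step of this kind to lean on, the change is expected to make little difference, a 1.3-fold lower number from compound 2 to compound 3 (0.11 log units; within the scatter). Compound 3 is therefore estimated at 110 nM, with a likely range from 35 nM to 350 nM.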

Compound 3, half-maximal inhibitory concentration: 54 nM
The estimate for compound 3 lay 2.0-fold (0.31 log units) above the measured number; low and high end bracket the measured number.
By their numbers in this assay, from the lowest: compound 3; then compounds 2 and 1 (each within the scatter of the next).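

For the compounds shown here, this is the first measured step at this place on the chain: in this assay, piperidin-1-yl in place of 2-(dimethylamino)ethyl gives a 2.6-fold lower number from compound 2 to compound 3 (0.42 log units; beyond the scatter) and so lies beyond the scatter, though the step is modest. It shows that this swap can shift binding, with the ring-bearing compound 3 on the lower side. No measurement here explains the shift.

Still open, from the compounds shown here alone, is whether a pyrrolidine or a morpholine in this place would shift the number further. Going by these compounds, it is also open whether a longer chain would keep the shift.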